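Swapping benzyl for cyclohexyl on the side chain of compound 1

The source may report more compounds than this note shows. Statements on the series, on what has been measured and on what is new or still open speak of the compounds shown alone.

The measured compounds:
Compound 1 `CN1CCC[C@@H]1Cn1nc(CCc2ccccc2)c2ccccc2c1=O` gives 200 nM in an assay for binding affinity to Alpha-1B adrenergic receptor (Homo sapiens); on this read-out higher numbers stand for weaker inhibition and lower numbers for stronger inhibition.
Compound 2 `COc1ccc(Cc2nn(C[C@H]3CCCN3C)c(=O)c3ccccc23)cc1OC` reaches only a limit of this assay, > 1990 nM, and no number is known for it.
Compound 3 `CN1CCC(n2nc(Cc3ccc(Cl)cc3)c3ccccc3c2=O)CC1` gives 6.31 nM in this assay.

Among the two numbers shown, compound 1 stands highest. Its nearest neighbour, compound 3, lies well below it, a gap beyond the scatter of repeated measurement. Compound 2 contributes nothing to the ordering because it sits at the limit of > 1990 nM in this assay, at which 1 of the 3 values shown sits.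

Compound 4 `CN1CCC[C@@H]1Cn1nc(CC2CCCCC2)c2ccccc2c1=O` differs from compound 1 in one place: cyclohexyl in place of benzyl on a saturated chain carbon bound to an aromatic carbon. For the measured compounds named here, no pair of measured compounds shows this change, so its size cannot be read off the numbers at hand. The writer expects the step of a 1.6-fold higher number from compound 1 to compound 4 (0.20 log units; within the scatter) to be modest, leaning if anything toward a higher number, and quite possibly within the scatter. Compound 4 is therefore estimated to give 320 nM in this assay, with a range from 90 nM to 1200 nM.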

Compound 4, inhibition constant: > 1990 nM
Compound 4: only a limit was reported (the forecaster's own chance of this, stated with the estimate: 15%); middle value at least 6.2-fold (0.79 log units) away from the limit.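

In this assay, cyclohexyl in place of benzyl on a saturated chain carbon bound to an aromatic carbon gives an at least 9.9-fold higher number from compound 1 to compound 4 (0.99 log units; beyond the scatter) and so is far from a neutral exchange at this position. For the compounds shown here, the earlier compounds all carried an aromatic ring at the end of this side chain, and only this pair shows that a non-aromatic ring of carbon only, in the same place, costs clear binding affinity. On these data alone, the value of compound 4 is a limit of the assay and not a number, so the full size of the step remains unknown: the limit of > 1990 nM in this assay, at which 2 of the 4 values shown sit.

As far as these compounds go, whether a pyridyl ring or an open hexyl chain would keep the number close to that of compound 1 remains open. So does whether the same exchange would cost as much on a compound with a different amine side chain.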